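The source may report more compounds than this note shows. Statements on the series, on what has been measured and on what is new or still open speak of the compounds shown alone.

In an ADME assay for pharmacokinetics, read by LC-MS, in phosphate buffer, with a stated time of 120 min, at pH 7.4, tested at 1 uM, in the presence of a further agent that is not named here (on this read-out higher numbers stand for a longer-lived compound and lower numbers for a shorter-lived compound), compound 1 (`O=C(/C=C/CF)Nc1ccccc1`) gives > 8.53 h, which is a limit of the assay and not a number. Compound 2 (`C=C(C)C(=O)Nc1ccccc1`) gives > 8.53 h, which is also a limit. Compound 1 therefore stands at the limit of > 8.53 h in this assay, at which 2 of the 3 values shown sit. Compound 3 (`O=C(/C=C/C(F)(F)F)Nc1ccccc1`) gives a true number, 0.267 h.

Compound 4 (`O=C(/C=C/CN1CCCCC1)Nc1ccccc1`) has piperidin-1-yl in place of fluoro on a saturated chain carbon bound to a double-bonded chain carbon. The incoming group is much larger than the one that leaves, and it brings a six-membered non-aromatic ring.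

Among the measured compounds shown here, two measured steps bear on this change, though neither involves that group. The exchange of fluoromethyl for trifluoromethyl gives an at least 31-fold lower number from compound 1 to compound 3 (1.50 log units; beyond the scatter), which shows that a change on this chain can shorten the half-life sharply. The other gives a step that the two limits leave unreadable from compound 1 to compound 2, so it sets no size. For the measured compounds named here, with only these steps to go on, a lower number is the likelier direction for compound 4, but a fall as deep as the one seen for compound 3 at 0.267 h seems less likely. Compound 4 may also reach the limit of the assay. The expected size of the step is an at least 1.7-fold lower number from compound 1 to compound 4 (0.23 log units; that floor lies within the scatter). For compound 4 the estimated half-life is 5 h, with an expected range from 1.5 h to 16 h.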

Compound 4, half-life: 2.95 h
Compound 4: middle estimate off by 1.7-fold (0.23 log units), on the high side, and the stated range covers the measured number.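

In this assay, this saturated chain carbon bound to a double-bonded chain carbon now has a second change that gives a true number: piperidin-1-yl in place of fluoro gives an at least 2.8-fold lower number from compound 1 to compound 4 (0.46 log units; beyond the scatter), a step beyond the scatter. Shortening at this place therefore does not depend on adding more fluorine, as compound 3 alone might have suggested, since the group in compound 4 holds only carbon and nitrogen. The printed step is only a floor, and the true drop could be larger, because compound 1 sits at a limit rather than at a number: the limit of > 8.53 h in this assay, at which 2 of the 4 values shown sit.

Still open, as far as these compounds go, is which feature of the piperidin-1-yl group goes with the lower number: its nitrogen, its ring or simply its size. Placing an open-chain amine such as dimethylamino, a morpholin-4-yl ring or an all-carbon cyclohexyl ring on the same carbon would help to separate these features, while a compound with a true number in place of the limit would be needed to fix the size of such steps.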